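The compounds below may be only part of what the source reports. "The series", "measured", "known", "first", "only" and "open" are said of these compounds alone.

Measured so far in a functional assay on BXPC-3 cells (Homo sapiens) for inhibition, read by MTT assay, with a stated time of 7 days; a higher number here means a weaker inhibitor, a lower number a stronger inhibitor: compound 1 `CCC(CC)S(=O)(=O)c1ccc(S(=O)(=O)N2CCC[C@@H](C(=O)N3CCC(F)(F)CC3)C2)cc1` gives 40 nM, and compound 2 `CCN(CC)S(=O)(=O)c1ccc(S(=O)(=O)N2CCC[C@@H](C(=O)N3CCC(C(F)F)CC3)C2)cc1` gives 450 nM.

Compound 1 stands at the lower of these two numbers, and its gap to compound 2 lies beyond the usual scatter. Compound 3 `CC(C)CS(=O)(=O)c1ccc(S(=O)(=O)N2CCC[C@@H](C(=O)N3CCC(F)(F)CC3)C2)cc1` has not yet been measured. It differs from compound 1 in a single place: isobutyl in place of pentan-3-yl on a sulfonyl sulfur. Going by the values given here, no measured pair shows a step of this kind, so the expectation rests on compound 1 alone. Trading one short branched chain for another is expected to move the number little. The step of a 1.5-fold higher number from compound 1 to compound 3 (0.18 log units; within the scatter) is expected to be small, if anything toward a slightly higher number, and may stay within the scatter. Compound 3 is therefore estimated at 60 nM, within a range from 20 nM to 200 nM.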

Compound 3, half-maximal inhibitory concentration: 311 nM
Compound 3: the middle estimate sits 5.2-fold (0.71 log units) below what was measured, and the stated range ends below it.
By their numbers in this assay, from the lowest: compound 1; then compounds 3 and 2 (each within the scatter of the next).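

In this assay, isobutyl in place of pentan-3-yl on a sulfonyl sulfur gives a 7.8-fold higher number from compound 1 to compound 3 (0.89 log units; beyond the scatter), so this position responds clearly to a change from one branched carbon chain to another. Neither group carries a ring, a hydrogen-bond donor or acceptor, or a net charge, so the two differ only in their carbon chains. Nothing at hand explains why this small change matters so much.

Still open, as far as these compounds go, is how a straight pentyl chain, a cyclopentyl ring or an amine would behave on this sulfonyl sulfur.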